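The source may report more compounds than this note shows. Statements on the series, on what has been measured and on what is new or still open speak of the compounds shown alone.

Three compounds share one core and were tested in a functional assay on cells (T-cell, Mus musculus) for inhibition; a higher number here means a weaker inhibitor, a lower number a stronger inhibitor. Compound 1 `O=C(/C=C/c1cccc(F)c1)Nc1ccc2c(c1)COC2=O` gives 34 nM. Compound 2 `CCCNC(=O)Nc1ccc2c(c1)COC2=O` gives 58100 nM, and compound 3 `O=C(Nc1ccccc1)C(=O)Nc1ccc2c(c1)COC2=O` gives 36100 nM. Compound 3 thus stands second highest of the three numbers: its number and that of compound 2 lie within the scatter of each other, while compound 1 sits far lower, beyond the scatter. Compound 4 `O=C(Nc1ccc(Cl)cc1)C(=O)Nc1ccc2c(c1)COC2=O` differs from compound 3 by a single change: chloro in place of hydrogen on an aromatic carbon. Within the data shown here, no measured pair here shows what this change does, so the expectation rests on compound 3 alone. A small step toward a lower number is expected, possibly within the scatter, and the estimated step is a 1.8-fold lower number from compound 3 to compound 4 (0.26 log units; within the scatter). For compound 4 the expected value is 20000 nM, with a range from 5000 nM to 80000 nM.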

Compound 4, half-maximal inhibitory concentration: 2240 nM
The estimate for compound 4 lay 8.9-fold (0.95 log units) above the measured number; measured number below the stated range.
By their numbers in this assay, from the lowest: compound 1; then compound 4; then compounds 3 and 2 (each within the scatter of the next).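

In this assay, putting chloro on the aromatic carbon para to a large group gives a 16-fold lower number from compound 3 to compound 4 (1.21 log units; beyond the scatter), so this position responds strongly to the addition of a single heavy atom. Among these compounds, this is the first single change that can be read directly, and it shows that the phenyl end of compound 3 is not indifferent to substitution. Nothing measured here explains the size of this step. As far as these compounds go, it remains open whether fluoro, methyl or methoxy at the same carbon would give a similar step, and whether chloro elsewhere on that ring would do so.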